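This account rests on a few compounds, and the source may have more. Where it says the series, first, only, none or still open, it means among the compounds named here.

In a functional assay on MCF7 cells (Homo sapiens) for cytotoxicity, read by MTT assay, with a stated time of 24 h (a higher number here means a weaker inhibitor, a lower number a stronger inhibitor), the three measured compounds stand as follows.

Compound 1, `S=C(SCc1nc2cc(Cl)c(Cl)cc2[nH]1)N1CCOCC1`: 5700 nM
Compound 2, `S=C(SCc1nc2cc(Cl)c(Cl)cc2[nH]1)N1CCN(c2ccccc2Cl)CC1`: 60200 nM
Compound 3, `CN1CCN(CCCSc2nc3ccccc3[nH]2)CC1`: 77900 nM

Compound 3 carries the highest of the three numbers. Its number and that of compound 2 lie within the usual scatter of each other, so the two cannot be separated on these data, while the number for compound 1 is lower by a gap that goes beyond the scatter. Compound 4, `CCOc1ccccc1N1CCN(CCCSc2nc3ccccc3[nH]2)CC1`, has not yet been measured. It differs from compound 3 in one place only: 2-ethoxyphenyl in place of methyl on an amine nitrogen in a ring. Within the data shown here, no pair of measured compounds differs in exactly this way, so the size of this change has not been seen directly, and compounds 1 and 2 differ from compound 3 in several places at once, which gives no clean guide. With nothing to point either way, the expected step is a 1.2-fold lower number from compound 3 to compound 4 (0.08 log units; within the scatter), not beyond the scatter. For compound 4 the expected value in this assay is therefore 65000 nM, with a range from 20000 nM to 200000 nM.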

Compound 4, half-maximal inhibitory concentration: 32700 nM
The estimate for compound 4 lay 2.0-fold (0.30 log units) above the measured number; measured number inside the range.
By their numbers in this assay, from the lowest: compound 1; then compounds 4, 2 and 3 (each within the scatter of the next, the first and the last beyond it).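

In this assay, putting 2-ethoxyphenyl in place of methyl on the ring amine nitrogen gives a 2.4-fold lower number from compound 3 to compound 4 (0.38 log units; beyond the scatter), a modest step and the first direct view of this change at this position. It shows that this nitrogen can carry a far larger group, with nine heavy atoms and an aromatic ring instead of a single carbon, without the number rising; here the number falls. No measurement shown explains why the number moves this way.

From the compounds shown here alone, it remains open whether the aromatic ring or its ethoxy group accounts for the step, which a plain phenyl group on the same nitrogen could help to separate. Going by these compounds, it is also open whether a small amine or a carboxylic acid on that ring would move the number in the same direction.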